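Removing the aryl substituent from a benzoylguanidine exchanger inhibitor

This account rests on a few compounds, and the source may have more. Where it says the series, first, only, none or still open, it means among the compounds named here.

Compound 1: `Cc1cc(Sc2cccc(Cl)c2)c(S(C)(=O)=O)cc1C(=O)N=C(N)N`, 37 nM
Compound 2: `Cc1cc(OC2CCCC2)c(S(C)(=O)=O)cc1C(=O)N=C(N)N`, 27 nM
Compound 3: `Cc1cc(-n2cccn2)c(S(C)(=O)=O)cc1C(=O)N=C(N)N`, 25 nM

Three compounds sharing one core were tested in a functional assay for inhibition of sodium/hydrogen exchanger (Oryctolagus cuniculus); on this read-out higher numbers stand for weaker inhibition and lower numbers for stronger inhibition. Compound 1 gives 37 nM, compound 2 gives 27 nM and compound 3 gives 25 nM. Compound 3 holds the lowest of the three numbers, but its steps to the others, a 1.5-fold lower number from compound 1 to compound 3 (0.17 log units; within the scatter) and a 1.1-fold lower number from compound 2 to compound 3 (0.03 log units; within the scatter), are within the scatter, as is a 1.4-fold lower number from compound 1 to compound 2 (0.14 log units; within the scatter); the three values cannot be ordered.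

Compound 4, `Cc1ccc(S(C)(=O)=O)cc1C(=O)N=C(N)N`, differs from compound 3 in one place: hydrogen in place of 1H-pyrazol-1-yl on an aromatic carbon. For the measured compounds named here, no measured step bears directly on this change, since every measured compound carries some group at that position; the three steps only show that exchanging one such group for another leaves this assay unchanged. On these data alone, removing the group altogether is untested, so the account treats it as a moderate step toward a higher number with a wide range: compound 4 is expected to give 150 nM, between 40 nM and 600 nM, meaning an estimated step of a 6.0-fold higher number from compound 3 to compound 4 (0.78 log units; beyond the scatter).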

Compound 4, half-maximal inhibitory concentration: 150 nM
Compound 4: middle estimate and measured number agree at the digits printed; low and high end bracket the measured number.
By their numbers in this assay, from the lowest: compounds 3, 2 and 1 (each within the scatter of the next); then compound 4.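

Removing the group altogether does what exchanging it did not in this assay where hydrogen gives a 6.0-fold higher number from compound 3 to compound 4 (0.78 log units; beyond the scatter) and also a 5.6-fold higher number from compound 2 to compound 4 (0.74 log units; beyond the scatter) and also a 4.1-fold higher number from compound 1 to compound 4 (0.61 log units; beyond the scatter) with each step beyond the scatter. Among the compounds shown, this position, ortho to a methylsulfonyl group, carries (3-chlorophenyl)sulfanyl, cyclopentyloxy or 1H-pyrazol-1-yl at numbers that cannot be ordered, and only the bare aromatic carbon stands apart from those three. No measurement shown here accounts for this difference.

The compounds shown leave open how little must stand at this position, since they do not tell whether a methoxy group, a fluorine or an amine would group with compound 3 or with compound 4. They also leave open whether a carboxylic acid there would keep the lower numbers.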